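Nitrophenyl isomer step in the cytotoxicity series

The source may report more compounds than this note shows. Statements on the series, on what has been measured and on what is new or still open speak of the compounds shown alone.

Compound 1 `Cc1nc2ccccc2n(CC(=O)N/N=C/c2ccc(N(C)C)cc2)c1=O`: 355000 nM
Compound 2 `Cc1ccc(S(=O)(=O)N2CC3(C[C@H]2C(=O)N/N=C/c2ccccc2[N+](=O)[O-])SCCS3)cc1`: 65000 nM
Compound 3 `COc1ccc(/C=N/NC(=O)Cn2c(=O)c(C)nc3ccccc32)cc1OC`: > 526000 nM (a limit)

In a functional assay on C8166 cells (Homo sapiens) for cytotoxicity, read by MTT assay, with a stated time of 72 h (on this read-out lower numbers stand for higher toxicity in this test and higher numbers for lower toxicity in this test), compound 2 gives 65000 nM, the lower of the two actual numbers. Compound 1 gives 355000 nM. The gap between these two numbers lies beyond the scatter. Compound 3 has only a limit, > 526000 nM.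

Compound 4 `Cc1ccc(S(=O)(=O)N2CC3(C[C@H]2C(=O)N/N=C/c2cccc([N+](=O)[O-])c2)SCCS3)cc1` has 3-nitrophenyl in place of 2-nitrophenyl on a carbon with a double bond to nitrogen. For the measured compounds named here, no measured pair shows a comparable change. In this assay no shift beyond the scatter is expected, and neither direction is favoured. The estimated step, a 1.1-fold higher number from compound 2 to compound 4 (0.03 log units; within the scatter), is therefore small. The expected value for compound 4 is 70000 nM, with an estimated range of 25000 nM to 200000 nM.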

Compound 4, half-maximal cytotoxic concentration: > 395000 nM
Compound 4 ended at the assay's limit (the forecaster's own chance of this, stated with the estimate: 10%); middle value at least 5.6-fold (0.75 log units) from the limit.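

In this assay, 3-nitrophenyl in place of 2-nitrophenyl on a carbon with a double bond to nitrogen gives an at least 6.0-fold higher number from compound 2 to compound 4 (0.78 log units; beyond the scatter). For the compounds shown here, this position therefore responds to a shift of the nitro group alone, with atoms and counts unchanged, which no earlier pair could show. The size of the step has only a lower bound, since compound 4 stands at a limit of the assay: the limit of > 395000 nM in this assay, at which 1 of the 4 values shown sits.

Open: how an aminophenyl or a carboxyphenyl would behave at this place on the core of compound 2, and how far beyond its limit the true number of compound 4 lies.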